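Solubility notes: nitroaryl replaces bromophenol on the enone

The compounds below may be only part of what the source reports. "The series", "measured", "known", "first", "only" and "open" are said of these compounds alone.

Compound 3 `O=C(O)c1ccc(C(=O)/C(=C\c2ccc(O)c(Br)c2)SCc2ccc(Br)cc2)cc1` has been measured in a physicochemical assay for solubility; on this read-out lower numbers stand for lower solubility and higher numbers for higher solubility. In this assay compound 3 gives < 1000 ug/mL, which is a limit of the assay and not a number. Compound 1 `O=C(O)c1ccc(C(=O)/C(=C\c2ccc(Cl)c([N+](=O)[O-])c2)SCc2ccccc2F)cc1` gives < 1000 ug/mL, also a limit. Compound 2 `O=C(O)c1ccc(C(=O)/C(=C\c2ccc([N+](=O)[O-])c(F)c2)SCc2ccc(Br)cc2)cc1` gives < 1000 ug/mL, again a limit. Going by the values given here, the one step between measured neighbours, a step that the two limits leave unreadable from compound 2 to compound 3, cannot be read, and compound 3 stands exactly where the whole series stands: the limit of < 1000 ug/mL in this assay, at which 3 of the 3 values shown sit.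

Compound 4 `O=C(O)c1ccc(C(=O)/C(=C\c2ccc(Cl)c([N+](=O)[O-])c2)SCc2ccc(Br)cc2)cc1` differs from compound 3 as follows: 4-chloro-3-nitrophenyl in place of 3-bromo-4-hydroxyphenyl on a double-bonded chain carbon bound to a double-bonded chain carbon. Compound 1 already carries the 4-chloro-3-nitrophenyl group that enters, and compound 2 shares with compound 4 every part of the structure apart from the group that changes; both sit at the limit. Among the compounds with values here, no measured step bears readable size on this change, so no step beyond the scatter can be claimed in either direction.

Compound 4 is therefore expected to give 100 ug/mL in this assay, within 10 ug/mL to 1000 ug/mL, most likely reported as a limit. The expected step that the limit leaves unreadable from compound 3 to compound 4 is an estimate only.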

Compound 4, solubility: < 1000 ug/mL
Compound 4 was reported as a limit (the forecaster's own chance of this, stated with the estimate: 85%); the middle value is on the limit's open side.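

No new step can be read: compound 1, compound 2, compound 3 and compound 4 all stand at a limit in this assay, so the steps among them stay unreadable: the limit of < 1000 ug/mL in this assay, at which 4 of the 4 values shown sit.

The compounds shown leave open where any of these four actually lies in this assay, and whether 4-chloro-3-nitrophenyl and 3-bromo-4-hydroxyphenyl differ there at all.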